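This account rests on a few compounds, and the source may have more. Where it says the series, first, only, none or still open, it means among the compounds named here.

Measured so far:
compound 1, `COc1cc2ncnc(Nc3ccc(Cl)cc3)c2cc1OCCCCC(=O)Nc1ccc(S(N)(=O)=O)cc1`, in a functional assay on A-431 cells (Homo sapiens) for antiproliferative activity, read by MTT assay, with a stated time of 72 h; a higher number here means a weaker inhibitor, a lower number a stronger inhibitor: 7120 nM
compound 2, `COc1cc2ncnc(Nc3cccc(Cl)c3F)c2cc1OCCCCC(=O)Nc1ccc(S(N)(=O)=O)cc1`, in this assay: 5560 nM

Compound 2 holds the lowest of the two numbers in this assay, but its nearest neighbour is compound 1 at a 1.3-fold lower number from compound 1 to compound 2 (0.11 log units; within the scatter), so the two compounds stand level within the scatter and no order between them is claimed.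

The next compound, compound 3, `COc1cc2ncnc(Nc3cccc(C)c3)c2cc1OCCCCC(=O)Nc1ccc(S(N)(=O)=O)cc1`, differs from compound 2 in one place: 3-methylphenyl in place of 3-chloro-2-fluorophenyl on a nitrogen on an aromatic ring.

Among the compounds with values here, only one measured step touches the same position, the aryl group on the nitrogen on the aromatic ring: the exchange from compound 1 to compound 2, which gave a 1.3-fold lower number from compound 1 to compound 2 (0.11 log units; within the scatter) and stayed within the scatter. That step swaps one halogenated phenyl for another, whereas the present step removes both halogens in favour of a methyl, so it is a looser guide. On this basis no movement beyond the scatter is expected in this assay for compound 3, with a wide range to cover the weak footing.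

Compound 3 is therefore estimated at 6500 nM in this assay, within 2500 nM to 17000 nM.

The estimated step from compound 2 to compound 3 is a 1.2-fold higher number from compound 2 to compound 3 (0.07 log units; within the scatter), expected to lie within the scatter.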

Compound 3, half-maximal inhibitory concentration: 7460 nM
Estimate against measurement, compound 3: 1.1-fold (0.06 log units) below; the range from low to high includes it.
By their numbers in this assay, from the lowest: compounds 2, 1 and 3 (each within the scatter of the next).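

Halogen on the aryl group is not needed to hold the number at this position: 3-methylphenyl carries no halogen, yet it stands level with both halogenated groups in this assay, with a 1.3-fold higher number from compound 2 to compound 3 (0.13 log units; within the scatter) and a 1.0-fold higher number from compound 1 to compound 3 (0.02 log units; within the scatter) as the two new steps. The earlier pair compared only one halogenated phenyl with another, whereas these steps extend the comparison to a methyl-bearing ring and show no separation among the three aryl groups on the nitrogen on the aromatic ring. Nothing available accounts for this flat response at the position.

Still open, on these data alone, is whether a larger change to this aryl group, such as a ring bearing a carboxylic acid, a dimethylamino group or a methoxy group, would move the number in this assay beyond the scatter. The compounds shown also leave open whether a shorter or longer chain between the shared core and the amide would do so, since that part is the same in compound 1, compound 2 and compound 3.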